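A few compounds are considered here, and "the series" means these few. Any claim that something is new, unique, unknown or untested is made for them only; others in the source may bear on it.

Working notes on the series. For the measured compounds named here, in an ADME assay on CCRF-CEM cells (Homo sapiens) for antiproliferative activity, with a stated time of 48 h (on this read-out lower numbers stand for stronger inhibition and higher numbers for weaker inhibition), compound 1 `Nc1ccc(/C=C/C(=O)c2ccc(I)cc2)cc1` gives 16000 nM and compound 2 `Cc1ccc(C(=O)/C=C/c2ccc(N)cc2)cc1` gives 31000 nM, so compound 2 stands within the scatter of the only other measured compound. Compound 3 `COc1ccc(C(=O)/C=C/c2ccc(N)cc2)cc1` has methoxy in place of methyl on an aromatic carbon. Going by the values given here, the one measured step that bears on this change is a 1.9-fold higher number from compound 1 to compound 2 (0.29 log units; within the scatter), made at the same place on the shared core. That step stays within the scatter, so no step beyond the scatter is expected in this assay. Compound 3 is estimated at 25000 nM, with an expected range of 10000 nM to 60000 nM.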

Compound 3, half-maximal inhibitory concentration: 37000 nM
Compound 3: middle estimate off by 1.5-fold (0.17 log units), on the low side; the range from low to high includes it.
By their numbers in this assay, from the lowest: compounds 1, 2 and 3 (each within the scatter of the next, the first and the last beyond it).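

In this assay methoxy in place of methyl gives a 1.2-fold higher number from compound 2 to compound 3 (0.08 log units; within the scatter) and so does not separate from methyl on this aromatic carbon, para to a large group. Methoxy in place of iodo gives a 2.3-fold higher number from compound 1 to compound 3 (0.36 log units; beyond the scatter) and is the only step so far beyond the scatter, though a modest one. No measurement on hand offers a reason for either step. Going by these compounds, whether an amine or a carboxylic acid at this place would stand beyond the scatter of methyl remains open, as does whether the iodo to methoxy step holds on any other core.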